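The source may hold more compounds than are shown below. What is called first, only, known or untested is meant among the compounds shown, and "the series" means these compounds.

Of the compounds shown here, three of a shared core have been tested in a functional assay on M14 cells (Homo sapiens) for cytotoxicity, read by sulforhodamine B assay, with a stated time of 48 h, tested at 100 uM; on this read-out higher numbers stand for a weaker effect at the one concentration tested and lower numbers for a stronger effect. Compound 1 `COc1ccc(-c2cc(/C=C/C(=O)c3ccc(N)cc3)[nH]n2)cc1` gives -71% in this assay, compound 2 `COc1cc(-c2cc(/C=C/C(=O)c3ccc(N)cc3)[nH]n2)cc(OC)c1OC` gives -78%, and compound 3 `COc1cc(-c2cc(/C=C/C(=O)c3ccc(F)c(F)c3)[nH]n2)cc(OC)c1OC` gives -38%. Compound 2 thus holds the lowest of the three numbers, though its value and that of compound 1 lie within the scatter of each other, so no order between the two can be claimed. Within the data shown here, the one step measured between neighbouring structures is the exchange of 3,4-difluorophenyl for 4-aminophenyl on the carbonyl carbon, which gave a number 40 percentage points higher from compound 2 to compound 3 (beyond the scatter).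

Compound 4 `COc1ccc(-c2cc(/C=C/C(=O)c3ccc(N)cc3)[nH]n2)cc1OC` has not yet been tested in this assay. It differs from compound 2 in one place: hydrogen in place of methoxy on an aromatic carbon. The measured step from compound 2 to compound 3 concerns a different part of the molecule and therefore says little about this change. Compound 1 and compound 2 differ in two methoxy groups rather than one, and their values in this assay lie within the scatter of each other, which suggests that the methoxy count has little bearing on the read-out. The step from compound 2 to compound 4 is therefore expected to be a number 4 percentage points higher from compound 2 to compound 4 (within the scatter), not beyond the scatter. Compound 4 is estimated to give -74% in this assay, between -88% and -58%.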

Compound 4, a percentage reported as activity, at one concentration (the size of the read-out at that concentration, not a potency): -90%
Compound 4: middle estimate off by 16 percentage points, on the high side; measured number below the stated range.
By their numbers in this assay, from the lowest: compound 4; then compounds 2 and 1 (each within the scatter of the next); then compound 3.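

In this assay, hydrogen in place of methoxy on the aromatic carbon that stands ortho to a methoxy group, meta to a large group and meta to a methoxy group gave a number 12 percentage points lower from compound 2 to compound 4 (beyond the scatter). This shows that a single methoxy group on this ring can shift the read-out beyond the scatter, which no earlier step had shown. The opposite kind of change, methoxy in place of hydrogen on an aromatic carbon, gave a number 19 percentage points lower from compound 1 to compound 4 (beyond the scatter), so adding a methoxy group and removing one both led to compound 4 with a lower number, and no simple rule of more or fewer methoxy groups fits these steps; nothing available explains this result.

The compounds shown leave open whether a hydroxy group, an ethoxy group or a chlorine atom on this aromatic carbon would act as methoxy or hydrogen does here. They also leave open whether the same steps would hold with the 3,4-difluorophenyl group of compound 3 in place of the 4-aminophenyl group on the carbonyl carbon.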